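Cyclohexyl replaces pyridin-4-yl on the propenyl chain

A few compounds are considered here, and "the series" means these few. Any claim that something is new, unique, unknown or untested is made for them only; others in the source may bear on it.

The series shares a core carrying a hydroxy(phenyl)methyl group, an aryl substituent and a prop-2-en-1-yl chain that ends in a ring. In a functional assay on HL-60 cells (Homo sapiens) for cytotoxicity, read by WST assay, with a stated time of 48 h (on this read-out higher numbers stand for weaker inhibition and lower numbers for stronger inhibition), compound 1 `Cc1ccc(/C=C/C[C@H]2C[C@@H]([C@@H](O)c3ccccc3)CO[C@@H]2c2ccccc2)cc1C` gives 9880 nM. Compound 3 `COc1ccc(/C=C/C[C@@H]2C[C@@H]([C@@H](O)c3ccc(OC)c(OC)c3)CO[C@H]2c2ccc(OC)c(OC)c2)cc1OC` gives 26000 nM in this assay. Compound 2 `O[C@@H](c1ccccc1)[C@H]1CO[C@H](c2ccccc2)[C@@H](C/C=C/c2ccncc2)C1` reaches only the limit of this assay, reported as > 100000 nM, so for compound 2 a bound and no number is known. Going by the values given here, compound 2 is the one of the three values that sits at this limit (the limit of > 100000 nM in this assay, at which 1 of the 3 values shown sits).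

Among the compounds with values here, the step of an at least 10-fold higher number from compound 1 to compound 2 (1.00 log units; beyond the scatter) is the only measured step that bears on the change now considered, and because it ends at the limit of > 100000 nM in this assay, at which 1 of the 3 values shown sits, its size is a lower bound.

Compound 4 `O[C@@H](c1ccccc1)[C@H]1CO[C@H](c2ccccc2)[C@@H](C/C=C/C2CCCCC2)C1` differs from compound 2 as follows: cyclohexyl in place of pyridin-4-yl on a double-bonded chain carbon bound to a double-bonded chain carbon. Cyclohexyl, like 3,4-dimethylphenyl in compound 1 and unlike pyridin-4-yl, carries no hydrogen-bond acceptor, so the change is expected to run opposite to an at least 10-fold higher number from compound 1 to compound 2 (1.00 log units; beyond the scatter) and give a lower number. The expected step is an at least 6.6-fold lower number from compound 2 to compound 4 (0.82 log units; beyond the scatter), its size uncertain since compound 2 is only a limit. Compound 4 is therefore estimated at 15000 nM, with a range from 4000 nM to 100000 nM.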

Compound 4, half-maximal inhibitory concentration: 6260 nM
Estimate against measurement, compound 4: 2.4-fold (0.38 log units) above; measured number inside the range.
By their numbers in this assay, from the lowest: compounds 4 and 1 (each within the scatter of the next); then compound 3. At a limit, above all of these: compound 2.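

Cyclohexyl on a double-bonded chain carbon bound to a double-bonded chain carbon gives an at least 15-fold lower number from compound 2 to compound 4 (1.20 log units; beyond the scatter) in this assay when it replaces pyridin-4-yl, so a non-aromatic ring of carbon only now shows the change in the opposite direction to the earlier step. Set against 3,4-dimethylphenyl, the same group gives a 1.6-fold lower number from compound 1 to compound 4 (0.20 log units; within the scatter) and this lies within the scatter, so compound 1 and compound 4 cannot be told apart and an aromatic ring at the chain end is not required for activity in this range. Compound 2 remains a limit and not a number, so the size of its step to cyclohexyl is only a lower bound: the limit of > 100000 nM in this assay, at which 1 of the 4 values shown sits.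

On these data alone, whether the ring nitrogen of pyridin-4-yl is what separates compound 2 from the others stays open, since compound 2 alone carries it here, and a plain phenyl, a pyridin-3-yl or a piperidin-4-yl with its amine at the chain end would help to settle that. Also open, as far as these compounds go, is whether a ring is needed at all, which an open n-butyl end in place of cyclohexyl would test.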